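Aryl swap at the pyridine flank: chloro for methyl

The source may hold more compounds than are shown below. What is called first, only, known or untested is meant among the compounds shown, and "the series" means these compounds.

Compound 3 `Cc1ccc(-c2cc(-c3ccc(Cl)o3)cc(-c3cccs3)n2)cc1` sits at the top of the three numbers in hand: in an assay on isolated protein for inhibition of DNA topoisomerase 1 (Homo sapiens), tested at 100 uM (a higher number here means a stronger effect of the compound at the concentration tested, a lower number a weaker effect), compound 3 gives 41.8%. Its neighbour compound 2 `Clc1ccc(-c2cc(-c3cccs3)nc(-c3ccccc3Cl)c2)o1` gives 41.3%, and the two are not separated, as a number 0.5 percentage points higher from compound 2 to compound 3 (within the scatter) shows. Compound 1 `Clc1ccc(-c2cc(-c3ccco3)nc(-c3cccs3)c2)o1` gives 16% and lies well apart from both, as a number 25.3 percentage points higher from compound 1 to compound 2 (beyond the scatter) and a number 25.8 percentage points higher from compound 1 to compound 3 (beyond the scatter) show.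

Compound 4 `Clc1ccc(-c2cc(-c3ccc(Cl)o3)cc(-c3cccs3)n2)cc1` is the next member, differing from compound 3 by chloro in place of methyl on an aromatic carbon. Within the data shown here, the only measured step that bears on this kind of change is the one from compound 2 to compound 3, where one substituted phenyl replaced another and a number 0.5 percentage points higher from compound 2 to compound 3 (within the scatter) stayed within the scatter. The two larger steps in the set both concern the exchange of furan-2-yl for a phenyl ring and say nothing about what is carried on that ring. A change from 4-methylphenyl to 4-chlorophenyl, para to a large group, is therefore expected to leave the read-out where compound 3 left it, with a step of a number 0.2 percentage points higher from compound 3 to compound 4 (within the scatter) that stays within the scatter. For compound 4 the estimate in this assay is 42%, with a range of 28% to 56%.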

Compound 4, a percentage reported as inhibition, at one concentration (the size of the read-out at that concentration, not a potency): 38.9%
Estimate against measurement, compound 4: 3.1 percentage points above; the measured number falls inside the stated range.
By their numbers in this assay, from the lowest: compound 1; then compounds 4, 2 and 3 (each within the scatter of the next).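

Chloro and methyl on an aromatic carbon, para to a large group, are not told apart in this assay: a number 2.9 percentage points lower from compound 3 to compound 4 (within the scatter), and this is the first step in the series that changes what the phenyl ring carries while leaving the 4-position occupied. The placement of chlorine on the phenyl ring is also not resolved by this read-out, with 2-chlorophenyl giving way to 4-chlorophenyl in a number 2.4 percentage points lower from compound 2 to compound 4 (within the scatter), while the separation from the furan-2-yl member now holds for a third phenyl ring, at a number 22.9 percentage points higher from compound 1 to compound 4 (beyond the scatter). Nothing measured on these compounds accounts for either the flat response among the phenyl rings or their gap to compound 1.

On these data alone, whether this flat response extends beyond chloro and methyl remains open, since an amine, a carboxylic acid or a longer chain at the same place could give a quite different read-out. Also open, as far as these compounds go, is how these single-concentration read-outs relate to potency, and whether the gap to compound 1 would persist with other rings in place of furan-2-yl.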